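A few compounds are considered here, and "the series" means these few. Any claim that something is new, unique, unknown or untested is made for them only; others in the source may bear on it.

Measured so far in a functional assay on NCI-H460 cells (Homo sapiens) for inhibition, read by sulforhodamine B assay, with a stated time of 48 h; on this read-out higher numbers stand for lower toxicity in this test and lower numbers for higher toxicity in this test:

- compound 1, `COc1ccc(-c2cc(/C=C/C(=O)c3ccc(N)cc3)[nH]n2)cc1`, gives 20900 nM
- compound 2, `COc1ccc(-c2cc(/C=C/C(=O)c3ccc(N)cc3)[nH]n2)cc1OC`, gives 10600 nM
- compound 3, `COc1cc(C(=O)/C=C/c2cc(-c3cc(OC)c(OC)c(OC)c3)n[nH]2)cc(OC)c1OC`, gives 9910 nM

Compound 2 and compound 1 differ in one place: hydrogen in place of methoxy on an aromatic carbon. That step gave a 2.0-fold higher number from compound 2 to compound 1 (0.29 log units; within the scatter). Compound 3 carries a different core from compound 2; the difference between the two cores is not broken down here. Compound 3 and compound 2 sit within the scatter of each other, while compound 1 gives a higher number than compound 3 by a gap beyond the scatter.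

Compound 4, `COc1ccc(-c2cc(/C=C/C(=O)c3cc(OC)c(OC)c(OC)c3)[nH]n2)cc1OC`, is still to be measured in this assay. It differs from compound 3 by hydrogen in place of methoxy on an aromatic carbon. This is the same kind of change as that from compound 2 to compound 1, but not the same: the place is here additionally meta to a methoxy group. The step from compound 3 to compound 4 is expected to be small, about a 1.8-fold higher number from compound 3 to compound 4 (0.26 log units; within the scatter), because the same kind of change gave a 2.0-fold higher number from compound 2 to compound 1 (0.29 log units; within the scatter). For compound 4 the expected value in this assay is 18000 nM, estimated to fall between 8000 nM and 40000 nM.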

Compound 4, concentration lethal to 50% of the cells: 29900 nM
The estimate for compound 4 lay 1.7-fold (0.22 log units) below the measured number; low and high end bracket the measured number.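

In this assay, hydrogen in place of methoxy on an aromatic carbon gave a 3.0-fold higher number from compound 3 to compound 4 (0.48 log units; beyond the scatter), so on this second core the change again goes with a higher number, which on this read-out means lower toxicity in this test. The earlier step on the other core, a 2.0-fold higher number from compound 2 to compound 1 (0.29 log units; within the scatter), lay within the scatter, but the two steps do not differ from each other beyond what two such steps can scatter, so the change carries over between these cores as far as can be read: the same change on two cores in this assay, a 2.0-fold higher number (0.29 log units; within the scatter) from compound 2 to compound 1 and a 3.0-fold higher number (0.48 log units; beyond the scatter) from compound 3 to compound 4, 1.5-fold (0.18 log units) apart, within the scatter of two such steps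

This rests on two pairs only and does not show that the step would hold on any further core, nor whether the methoxy group that stays meta to the place in compound 4 alters its size.

The compounds shown carry only hydrogen or methoxy at this carbon, so it remains open how a hydroxyl, a fluorine or an ethoxy group there would read. Also open, from the compounds shown here alone, is whether the step repeats when the methoxy groups around that place are replaced by other groups.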